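Swapping a bromophenyl for a quinoline on the exocyclic chain

The source may hold more compounds than are shown below. What is called first, only, known or untested is meant among the compounds shown, and "the series" means these compounds.

Of the compounds shown here, three sharing one core have been tested in a functional assay on HepG2 cells (Homo sapiens) for antiproliferative activity, read by MTT assay; on this read-out lower numbers stand for stronger inhibition and higher numbers for weaker inhibition. Compound 1 `O=C1N=C(N2CCC[C@H]2C(=O)Nc2ccc3ncnc(Nc4cccc(Cl)c4)c3c2)S/C1=C/c1cccs1` gives 4120 nM. Compound 2 `O=C1N=C(N2CCC[C@H]2C(=O)Nc2ccc3ncnc(Nc4cccc(Cl)c4)c3c2)S/C1=C/c1cccc(Br)n1` gives 2700 nM. Compound 3 `O=C1N=C(N2CCC[C@H]2C(=O)Nc2ccc3ncnc(Nc4cccc(Cl)c4)c3c2)S/C1=C/c1cccc(Br)c1` gives 21300 nM, the highest of the three numbers: there is a 5.2-fold higher number from compound 1 to compound 3 (0.71 log units; beyond the scatter) and a 7.9-fold higher number from compound 2 to compound 3 (0.90 log units; beyond the scatter), both beyond the scatter, while a 1.5-fold lower number from compound 1 to compound 2 (0.18 log units; within the scatter).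

Compound 4 `O=C1N=C(N2CCC[C@H]2C(=O)Nc2ccc3ncnc(Nc4cccc(Cl)c4)c3c2)S/C1=C/c1ccc2ccccc2n1` has not been measured. It differs from compound 3 in one place: quinolin-2-yl in place of 3-bromophenyl on a double-bonded chain carbon bound to a double-bonded ring carbon. Among the measured steps, the closest parallel is the change in the reverse direction at the same place between compound 2 and compound 3, where a group with a ring nitrogen gave the lower number, and compound 1 with thiophen-2-yl also sat well below compound 3. A quinolin-2-yl group brings back a ring nitrogen, so a step downward of similar size seems plausible, though the added ring is an untested feature. Compound 4 is therefore expected to give 3500 nM, with a range from 1200 nM to 10000 nM, which would mean an estimated 6.1-fold lower number from compound 3 to compound 4 (0.78 log units; beyond the scatter).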

Compound 4, half-maximal inhibitory concentration: 22900 nM
Estimate against measurement, compound 4: 6.5-fold (0.82 log units) below; the whole stated range lies below it.
By their numbers in this assay, from the lowest: compounds 2 and 1 (each within the scatter of the next); then compounds 3 and 4 (each within the scatter of the next).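

In this assay, a ring nitrogen at this place, on a double-bonded chain carbon bound to a double-bonded ring carbon, does not by itself give a low number: a 1.1-fold higher number from compound 3 to compound 4 (0.03 log units; within the scatter) leaves quinolin-2-yl and 3-bromophenyl indistinguishable, although only quinolin-2-yl has a hydrogen-bond acceptor. The two groups with a ring nitrogen also fall on opposite sides of the gap, with an 8.5-fold higher number from compound 2 to compound 4 (0.93 log units; beyond the scatter), and thiophen-2-yl, which has no ring nitrogen, sits on the lower side too, with a 5.6-fold higher number from compound 1 to compound 4 (0.74 log units; beyond the scatter). Nothing measured for these compounds accounts for this split.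

The compounds shown leave open whether the added ring of quinolin-2-yl or the missing bromine sets compound 4 apart from compound 2. An unsubstituted pyridin-2-yl group or a bromine-bearing quinolin-2-yl group at this place would help separate those two features.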